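The source may report more compounds than this note shows. Statements on the series, on what has been measured and on what is new or still open speak of the compounds shown alone.

Compound 1, `CC1=C(C(=O)CC(C)C)C(c2cccs2)NC(=O)N1`: 19%
Compound 2, `CC1=C(C(=O)OC2CCCC2)C(c2ccoc2)NC(=O)N1`: 6%
Compound 3, `CCC(CC)OC(=O)C1=C(C)NC(=O)NC1c1cccs1`: 13%

In an assay on membranes from CHO cells for displacement of a labelled ligand from adenosine receptor A1 (Homo sapiens), read by scintillation counting, with a stated time of 60 min, tested at 1 uM (a lower number here means less inhibition, a higher number more inhibition at the concentration tested (going by the name of the read-out)), compound 3 gives 13%. Its nearest neighbour in number is compound 1, and the step of a number 6 percentage points lower from compound 1 to compound 3 (within the scatter) lies within the scatter; compound 2 lies a little lower, also within the scatter, so the three measured numbers cannot be told apart.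

Compound 4, `CC1=C(C(=O)OC2CCCC2)C(c2cccs2)NC(=O)N1`, is not yet measured. Compared with compound 3 the change is cyclopentyl in place of pentan-3-yl on an oxygen next to a carbonyl group. For the measured compounds named here, the only measured step that touches the same place on the shared core is a number 6 percentage points lower from compound 1 to compound 3 (within the scatter), a swap of the group on the carbonyl carbon that moved the number by no more than the scatter. Compound 2, which carries the same cyclopentyl ester on a different ring, gives 6%, again a low number. Nothing here points to a step beyond the scatter, and a change of a number 2 percentage points lower from compound 3 to compound 4 (within the scatter) is expected. Compound 4 is therefore estimated at 11%, with a range from 0% to 25%.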

Compound 4, a percentage reported as inhibition, at one concentration (the size of the read-out at that concentration, not a potency): 9%
For compound 4 the middle estimate is 2 percentage points above the measured one, within the range that was stated.
By their numbers in this assay, from the lowest: compounds 2, 4, 3 and 1 (each within the scatter of the next, the first and the last beyond it).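

In this assay, for the compounds shown here, closing the ester group into one five-membered ring gives no step that can be read: cyclopentyl in place of pentan-3-yl on an oxygen next to a carbonyl group gives a number 4 percentage points lower from compound 3 to compound 4 (within the scatter). The two other single changes now available also stay inside the scatter, with thiophen-2-yl in place of furan-3-yl on a saturated ring carbon giving a number 3 percentage points higher from compound 2 to compound 4 (within the scatter) and cyclopentyloxy in place of isobutyl on a carbonyl carbon giving a number 10 percentage points lower from compound 1 to compound 4 (within the scatter). No measurement offers a reason for these small steps.

Going by these compounds, whether an amide or a carboxylic acid in place of the ester, or a phenyl ring in place of thiophen-2-yl, would move the number beyond the scatter stays open. The read-out at one concentration is not a potency, so the potencies of these compounds also remain open.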